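The source may hold more compounds than are shown below. What is called first, only, known or untested is meant among the compounds shown, and "the series" means these compounds.

Measured compounds:
compound 1, `Clc1ccc(OCC2=NCCO2)cc1`, 48.2%
compound 2, `Cc1ccccc1OCC1=NCCO1`, 29.5%
compound 3, `Cc1cc(OCC2=NCCO2)ccc1Cl`, 45.4%

In a functional assay on the whole organism for inhibition, with Rattus norvegicus as the target, read by paw edema, with a stated time of 30 min, at a dose of 40 mg/kg by the oral route (a higher number here means a stronger effect of the compound at the dose given, a lower number a weaker effect), compound 3 gives 45.4%, the second highest of the three numbers. Its nearest neighbour is compound 1 with 48.2%, a gap that lies within the scatter; furthest away is compound 2 with 29.5%, a gap beyond the scatter.

Compound 4, `Cc1cccc(OCC2=NCCO2)c1`, is not yet measured. It differs from compound 3 in one place: hydrogen in place of chloro on an aromatic carbon.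

Among the compounds with values here, only one step between measured compounds is known, a number 2.8 percentage points lower from compound 1 to compound 3 (within the scatter), and it concerns the methyl group, not the chloro group, so it does not bear directly on this change. What does bear on it is the pair of values without a step: compound 2, which carries a methyl group but no chloro group, gives 29.5% in this assay, well below the two compounds that carry a chloro group. Compound 4 likewise carries a methyl group and no chloro group, so a drop is expected for compound 4 in this assay, estimated as a number 12.4 percentage points lower from compound 3 to compound 4 (beyond the scatter). The estimated value of compound 4 is 33%, with an expected range from 20% to 46%.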

Compound 4, a percentage reported as inhibition, in the whole organism at one dose (the size of the read-out at that dose, not a potency): 44.6%
The estimate for compound 4 lay 11.6 percentage points below the measured number, within the range that was stated.
By their numbers in this assay, from the lowest: compound 2; then compounds 4, 3 and 1 (each within the scatter of the next).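

In this assay, hydrogen in place of chloro on the aromatic carbon ortho to a methyl group and para to a group of 7 heavy atoms gives a number 0.8 percentage points lower from compound 3 to compound 4 (within the scatter), so compound 3 and compound 4 cannot be told apart at this dose. Within the data shown here, this is the first direct reading of the chloro group at this position, since the earlier step concerned the methyl group and compound 2 differs from compound 3 in more than one place, which means that its lower number could not be tied to the chloro group alone. In this pair, the chlorine atom is not needed to keep the read-out at the level of compound 3, and nothing available explains why this is so.

The compounds shown leave open whether other groups at this position, such as a methoxy group, an amine or a carboxylic acid, would also leave the read-out within the scatter of compound 3. They also leave open whether hydrogen in place of chloro would give an equally small step on a ring without the methyl group.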